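This account rests on a few compounds, and the source may have more. Where it says the series, first, only, none or still open, it means among the compounds named here.

Measured compounds:
- compound 1, `CCN1CCN(c2cc(C)c3cc(NC(=O)c4ccccc4F)ccc3n2)CC1`: 32600 nM
- compound 2, `CCN1CCN(c2cc(C)c3cc(NC(=O)c4ccccc4Br)ccc3n2)CC1`: 27500 nM
- compound 3, `CCN1CCN(c2cc(C)c3cc(NC(=O)c4cccc(Br)c4)ccc3n2)CC1`: 11600 nM

In a functional assay on MCF7 cells (Homo sapiens) for antiproliferative activity, read by MTT assay, with a stated time of 72 h (a lower number here means a stronger inhibitor, a higher number a weaker inhibitor), compound 3 gives the lowest of the three numbers. Compound 3 differs from compound 2 by 3-bromophenyl in place of 2-bromophenyl on a carbonyl carbon, and that change gave a 2.4-fold lower number from compound 2 to compound 3 (0.37 log units; beyond the scatter). Compound 3 also stands apart from compound 1 by a 2.8-fold lower number from compound 1 to compound 3 (0.45 log units; beyond the scatter).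

The change that matters for the unmeasured compound has already been seen once. From compound 2 to compound 1 the change is fluoro in place of bromo on an aromatic carbon, and in this assay it produced a 1.2-fold higher number from compound 2 to compound 1 (0.07 log units; within the scatter). The unmeasured compound 4, `CCN1CCN(c2cc(C)c3cc(NC(=O)c4cccc(F)c4)ccc3n2)CC1`, arises from compound 3 by fluoro in place of bromo on an aromatic carbon. This is the same kind of change, but not the same: in the first case the place is described as ortho to a large group, in the second as meta to a large group. The difference between the two starting cores is the one described above between compound 2 and compound 3.

Because the earlier exchange gave a 1.2-fold higher number from compound 2 to compound 1 (0.07 log units; within the scatter), a step within the usual scatter, the step from compound 3 to compound 4 is expected to be similarly small, with compound 4 staying close to its parent. Going by the values given here, since only one example of the exchange exists, and at a different place, the expected step of a 1.1-fold higher number from compound 3 to compound 4 (0.05 log units; within the scatter) carries a wide margin. For compound 4 the estimate in this assay is 13000 nM, within a range from 6000 nM to 30000 nM.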

Compound 4, half-maximal inhibitory concentration: 8920 nM
For compound 4 the middle estimate is 1.5-fold (0.16 log units) above the measured one, within the range that was stated.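

In this assay, fluoro in place of bromo on the 3-bromophenyl group gave a 1.3-fold lower number from compound 3 to compound 4 (0.11 log units; within the scatter), and setting this beside the same exchange on the 2-bromophenyl group shows that the two steps agree: the same change on two cores in this assay, a 1.2-fold higher number (0.07 log units; within the scatter) from compound 2 to compound 1 and a 1.3-fold lower number (0.11 log units; within the scatter) from compound 3 to compound 4, 1.5-fold (0.19 log units) apart, within the scatter of two such steps

For these two pairs, then, the exchange carries from one core to the other as a step that cannot be told from repeat-measurement noise, but two pairs in one cell assay do not show that bromo and fluoro are interchangeable across the series, and they say nothing about why. The steps beyond the scatter appear only when a 3-fluorophenyl group takes the place of a 2-halophenyl group, with a 3.1-fold lower number from compound 2 to compound 4 (0.49 log units; beyond the scatter) and a 3.7-fold lower number from compound 1 to compound 4 (0.56 log units; beyond the scatter), both modest and in line with the earlier steps to compound 3, so among these four compounds the halogen's place on the phenyl ring counts for more than which of the two halogens it is.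

The compounds shown leave open whether this holds for other groups at the same place on the phenyl ring, such as chloro, methyl, methoxy or a nitrile. They also leave open what happens when the ethyl group on the shared core gives way to a longer chain.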